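This account rests on a few compounds, and the source may have more. Where it says the series, first, only, none or still open, it means among the compounds named here.

Compound 1 `COC(=O)N(C)CC#CCn1ccnc1` serves as the reference of this small set. In a functional assay on the whole organism for agonist activity, with Mus musculus as the target (a lower number here means that less compound is needed, a higher number that more compound is needed for the effect), compound 1 gives 4.5 mg/kg, the lowest of the three numbers, although its nearest neighbour sits within the scatter of it. Compound 3 `COC(=O)N(C)C(C)C#CCn1ccnc1` gives 8 mg/kg, a step of a 1.8-fold higher number from compound 1 to compound 3 (0.25 log units; within the scatter). Compound 2 `COC(=O)N(C)CC#CCN(C)C` gives 9.7 mg/kg, a step of a 2.2-fold higher number from compound 1 to compound 2 (0.33 log units; beyond the scatter). Compound 4 `CN(C)C(=O)N(C)CC#CCn1ccnc1` differs from compound 1 by dimethylamino in place of methoxy on a carbonyl carbon. For the measured compounds named here, neither measured step touches the carbonyl carbon, so no measured step bears directly on this change; the two steps that exist, at other places, were modest or within the scatter. Compound 4 is therefore expected to give a number close to that of compound 1, a step of a 1.3-fold higher number from compound 1 to compound 4 (0.12 log units; within the scatter), estimated at 6 mg/kg with a range from 3 mg/kg to 13 mg/kg.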

Compound 4, dose for half-maximal effect: > 100 mg/kg
Compound 4: no number, only a limit (the forecaster's own chance of this, stated with the estimate: 5%); middle value at least 16-fold (1.22 log units) away from the limit.
By their numbers in this assay, from the lowest: compounds 1, 3 and 2 (each within the scatter of the next, the first and the last beyond it). At a limit, above all of these: compound 4.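

For the compounds shown here, replacing methoxy with dimethylamino on the carbonyl carbon gives an at least 22-fold higher number from compound 1 to compound 4 (1.34 log units; beyond the scatter), the only large step in the set. In this assay compound 4 gives > 100 mg/kg, which is a limit of the assay and not a number. The carbonyl carbon therefore emerges as a far less forgiving place than the two places changed earlier, at least for this replacement.

Going by these compounds, whether any departure from methoxy has this effect, or dimethylamino specifically, stays open; ethoxy or methylamino on the carbonyl carbon would separate the two. On these data alone, whether the same change would act alike on compound 2 also stays open.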